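The source may report more compounds than this note shows. Statements on the series, on what has been measured and on what is new or still open speak of the compounds shown alone.

Working notes on the series.

Compound 1 `CCc1cccc(Nc2cc(NC(=O)Nc3cc(OC)cc(OC)c3)ncn2)c1` and compound 2 `COc1cc(NC(=O)Nc2cc(Nc3ccc(Br)cc3OC)ncn2)cc(OC)c1` share a core that carries a urea linked to a dimethoxyphenyl group and an aromatic nitrogen bearing an aryl substituent. In a functional assay on PC-9 cells (Homo sapiens) for inhibition, read by MTT assay, with a stated time of 48 h, tested at 10 uM (on this read-out higher numbers stand for more inhibition at the one concentration tested (going by the name of the read-out) and lower numbers for less inhibition), compound 1 gives 82.1%, and in this assay compound 2 gives 83%. Among the measured compounds shown here, the only step so far, a number 0.9 percentage points higher from compound 1 to compound 2 (within the scatter), exchanges the aryl group on that nitrogen and is within the scatter; compound 2 thus stands at the higher of the two numbers, with compound 1 within the scatter of it, so no order between them can be read.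

Compound 3 `COc1cc(NC(=O)Nc2cc(Nc3ccc(OC)c(I)c3)ncn2)cc(OC)c1` is the next member. Relative to compound 2 the change is 3-iodo-4-methoxyphenyl in place of 4-bromo-2-methoxyphenyl on a nitrogen on an aromatic ring. For the measured compounds named here, this is the same kind of exchange as the one measured step, which altered the aryl group on the nitrogen without moving this assay beyond the scatter. Going by the values given here, with one such step as the only guide, no shift beyond the scatter is expected for compound 3, so the expected step is a number 2 percentage points lower from compound 2 to compound 3 (within the scatter). Compound 3 is estimated at 81%, with a range from 66% to 92%.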

Compound 3, a percentage reported as inhibition, at one concentration (the size of the read-out at that concentration, not a potency): 47.1%
Compound 3: the middle estimate sits 33.9 percentage points above what was measured; the measured number lies below the stated range.
By their numbers in this assay, from the lowest: compound 3; then compounds 1 and 2 (each within the scatter of the next).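

In this assay the aryl group on a nitrogen on an aromatic ring proves not to be a free exchange: 3-iodo-4-methoxyphenyl in place of 4-bromo-2-methoxyphenyl gives a number 35.9 percentage points lower from compound 2 to compound 3 (beyond the scatter), and 3-iodo-4-methoxyphenyl in place of 3-ethylphenyl gives a number 35 percentage points lower from compound 1 to compound 3 (beyond the scatter). Among the compounds shown here, the one earlier step at this place stayed within the scatter, so only now does this position show that the read-out responds to the group it carries, with 3-ethylphenyl and 4-bromo-2-methoxyphenyl both well clear of 3-iodo-4-methoxyphenyl. Nothing at hand accounts for the drop.

The exchange of bromine for iodine and the different placing of the groups on the ring arrive together in this step, so the compounds shown do not separate the two. Also open, on these data alone, is how an aryl group carrying an amine or a carboxylic acid would read on this nitrogen, and whether the order of the three compounds holds at any concentration other than the one tested.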